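The compounds below may be only part of what the source reports. "The series", "measured", "known", "first", "only" and "open" are said of these compounds alone.

Working notes on a small hydrazone series tested in a functional assay on A549 cells (Homo sapiens) for cytotoxicity, read by MTT assay, with a stated time of 96 h; on this read-out lower numbers stand for stronger inhibition and higher numbers for weaker inhibition.

Compound 1 `O=C(N/N=C/c1ccco1)c1cc(-c2ccccc2)nn1Cc1ccc(Cl)nc1` is the reference point; in this assay compound 1 gives 26100 nM. Compound 2 `O=C(N/N=C/c1ccco1)c1cc(-c2ccc(Cl)cc2)nn1Cc1ccc(Cl)nc1` differs from it by one change, (chloro in place of hydrogen on an aromatic carbon). In this assay compound 2 gives 18700 nM. The step of a 1.4-fold lower number from compound 1 to compound 2 (0.14 log units; within the scatter) is therefore small, and the two values cannot be told apart on this read-out.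

Compound 3 `O=C(N/N=C/c1ccccc1O)c1cc(-c2ccccc2)nn1Cc1ccccc1` is built on a different core; the difference between the two cores is not broken down here. In this assay compound 3 gives 10800 nM, which sits within the scatter of compound 2 but beyond the scatter of compound 1.

Compound 4 `O=C(N/N=C/c1ccccc1O)c1cc(-c2ccc(Cl)cc2)nn1Cc1ccccc1` has not yet been measured. It differs from compound 3 by chloro in place of hydrogen on an aromatic carbon, the same change that was made between compound 1 and compound 2. Among the measured compounds shown here, the only guide to its effect is that single measured pair, where the change left the number essentially where it was. The step from compound 3 to compound 4 is expected to be a 1.4-fold lower number from compound 3 to compound 4 (0.13 log units; within the scatter) in this assay, because the matching step a 1.4-fold lower number from compound 1 to compound 2 (0.14 log units; within the scatter) stayed within the scatter. On that basis compound 4 is expected to give about 8000 nM in this assay. The estimate for compound 4 is expected to fall between 4000 nM and 16000 nM, the width reflecting that one pair is a thin basis and that the two cores have not been compared in any counted way.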

Compound 4, half-maximal inhibitory concentration: 4870 nM
Compound 4: middle estimate off by 1.6-fold (0.22 log units), on the high side; low and high end bracket the measured number.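

On the second core, the change from phenyl to 4-chlorophenyl gives a 2.2-fold lower number from compound 3 to compound 4 (0.35 log units; beyond the scatter) in this assay, so here the step can be read as a real one, whereas a 1.4-fold lower number from compound 1 to compound 2 (0.14 log units; within the scatter) on the core of compound 1 could not. Set side by side, the two steps cannot be told apart: the same change on two cores in this assay, a 1.4-fold lower number (0.14 log units; within the scatter) from compound 1 to compound 2 and a 2.2-fold lower number (0.35 log units; beyond the scatter) from compound 3 to compound 4, 1.6-fold (0.20 log units) apart, within the scatter of two such steps The number falls on both cores, which fits the change carrying over from one core to the other, but this rests on only two pairs, one of them inside the scatter, and it does not show that the size of the step is the same on both cores, that the core has no influence on it, or that it would hold on any further core.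

The compounds shown leave open whether the step belongs to chloro in particular or would also appear with fluoro, methoxy, an amine or a carboxylic acid on the same carbon of the aromatic ring. Among the compounds shown here, they also leave open which of the several differences between the core of compound 1 and the core of compound 3 matters in this assay, since no pair separates those differences one at a time.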